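From 4-methylphenyl to 2-methylphenyl at the assay limit

A few compounds are considered here, and "the series" means these few. Any claim that something is new, unique, unknown or untested is made for them only; others in the source may bear on it.

- Compound 1 `Fc1cccc(-c2nc(Nc3ccccc3F)c3cc(F)ccc3n2)c1` gives > 50000 nM (a limit)
- Compound 2 `Cc1ccc(Nc2nc(-c3cccc(F)c3)nc3ccc(F)cc23)cc1` gives > 50000 nM (a limit)

In a functional assay on HL-60 cells (Homo sapiens) for cytotoxicity, read by MTT assay, with a stated time of 48 h (a lower number here means a stronger inhibitor, a higher number a weaker inhibitor), compound 2 gives only a limit and no number. Compound 2 stands at the limit of > 50000 nM in this assay, at which 2 of the 2 values shown sit, with nothing to rank it further. Compound 3 `Cc1ccccc1Nc1nc(-c2cccc(F)c2)nc2ccc(F)cc12` differs through 2-methylphenyl in place of 4-methylphenyl on a nitrogen on an aromatic ring with 2-methylphenyl in place of 4-methylphenyl on a nitrogen on an aromatic ring. Among the compounds with values here, the one measured step bearing on this is a step that the two limits leave unreadable from compound 1 to compound 2 and it gives no size to carry over. No direction is expected, so the estimated a number no higher from compound 2 to compound 3 (the limit leaves the size open) is taken as none beyond the scatter. For compound 3 the estimate is 50000 nM with an expected range from 20000 nM to 100000 nM and another limit is likely.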

Compound 3, half-maximal inhibitory concentration: > 50000 nM
Compound 3: a limit, no number; the forecaster's own chance of this, stated with the estimate: 80%; the middle value lies on the limit itself.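

No step between compound 1, compound 2 and compound 3 can be read, as each gives only a limit and no number: the limit of > 50000 nM in this assay, at which 3 of the 3 values shown sit.

The compounds shown leave open whether 2-fluorophenyl, 4-methylphenyl and 2-methylphenyl differ in strength at all.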